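A Methyl Added at Two Different Places

The source may hold more compounds than are shown below. What is called first, only, known or untested is meant among the compounds shown, and "the series" means these compounds.

Compound 1 `Cc1ccccc1Nc1nc(Nc2ccc(N3CCN(C)CC3)cc2)ncc1Cl` is measured in a functional assay on MDA-MB-231 cells (Homo sapiens) for inhibition, read by CCK-8 assay, with a stated time of 48 h (a higher number here means a weaker inhibitor of growth, a lower number a stronger inhibitor of growth), and gives 7020 nM. Compound 2 `CCN1CCN(c2ccc(Nc3ncc(Cl)c(Nc4ccccc4C)n3)cc2)CC1` gives 3040 nM in this assay; the change from compound 1 to compound 2 is methyl in place of hydrogen on a saturated chain carbon bound to an amine nitrogen in a ring, and it brought a 2.3-fold lower number from compound 1 to compound 2 (0.36 log units; beyond the scatter). Compound 3 `CCc1ccc(Nc2nc(Nc3ccc(N4CCN(C)CC4)cn3)ncc2Cl)cc1` gives 5560 nM in this assay; the difference between the core of compound 3 and the core of compound 1 is not broken down here. Compound 4 `CC(C)c1ccc(Nc2nc(Nc3ccc(N4CCN(C)CC4)cn3)ncc2Cl)cc1` has not yet been measured. It differs from compound 3 by methyl in place of hydrogen on a saturated chain carbon bound to an aromatic carbon and a saturated chain carbon, the same kind of change as from compound 1 to compound 2 but not the same, since here the methyl enters on a saturated chain carbon bound to an aromatic carbon and a saturated chain carbon, whereas before it entered on a saturated chain carbon bound to an amine nitrogen in a ring. Among the compounds with values here, because the only measured example, a 2.3-fold lower number from compound 1 to compound 2 (0.36 log units; beyond the scatter), lowered the number modestly at a different place, compound 4 is expected to give a smaller step of a 1.3-fold lower number from compound 3 to compound 4 (0.12 log units; within the scatter). Compound 4 is therefore estimated at 4200 nM in this assay, between 1500 nM and 11000 nM.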

Compound 4, concentration for 50% growth inhibition: 7020 nM
Compound 4: middle estimate off by 1.7-fold (0.22 log units), on the low side; the measured number falls inside the stated range.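

In this assay, the added methyl gave a 1.3-fold higher number from compound 3 to compound 4 (0.10 log units; within the scatter), so ethyl and isopropyl cannot be told apart on this core. The methyl step therefore did not carry over from the earlier core, and the two steps differ: the same change on two cores in this assay, a 2.3-fold lower number (0.36 log units; beyond the scatter) from compound 1 to compound 2 and a 1.3-fold higher number (0.10 log units; within the scatter) from compound 3 to compound 4, 2.9-fold (0.46 log units) apart, beyond the scatter of two such steps This does not show whether the core or the place of the methyl accounts for the gap, as the two steps differ in both.

The compounds shown leave open how a longer chain, or an amine or a carboxylic acid, would fare in place of the isopropyl of the 4-isopropylphenyl group. Also open, going by these compounds, is whether a methyl entering at the same place on both cores would give matching steps.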